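A few compounds are considered here, and "the series" means these few. Any claim that something is new, unique, unknown or untested is made for them only; others in the source may bear on it.

For the measured compounds named here, compound 2 `O=C(Nc1cccc(Br)c1)Nc1cc(Oc2ccc3nc(NC(=O)C4CC4)sc3c2)ccc1F` gives the lowest number of the two measured so far: in a functional assay on HT-29 cells (Homo sapiens) for inhibition, read by luminescence and CellTiter-Glo, with a stated time of 12 h (on this read-out higher numbers stand for an effect only at larger amounts of compound and lower numbers for an effect already at smaller amounts), compound 2 gives 440 nM. Its nearest neighbour is compound 1 `CCOC(=O)c1cccc(NC(=O)Nc2cc(Oc3ccc4nc(NC(=O)C5CC5)sc4c3)ccc2F)c1`, which in this assay gives 7740 nM; the step of an 18-fold lower number from compound 1 to compound 2 (1.25 log units; beyond the scatter) came from bromo in place of ethoxycarbonyl on an aromatic carbon.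

Compound 3 `O=C(Nc1nc2ccc(Oc3ccc(F)c(NCc4cccc(C(F)(F)F)c4)c3)cc2s1)C1CC1` departs from compound 2 at a different place: 3-(trifluoromethyl)benzyl in place of (3-bromophenyl)carbamoyl on a nitrogen on an aromatic ring. Going by the values given here, the only measured step, an 18-fold lower number from compound 1 to compound 2 (1.25 log units; beyond the scatter), alters a substituent on the same aryl group that is now removed altogether, so it shows that the identity of that aryl ring matters strongly but does not tell what happens when the whole carbamoyl is exchanged for a benzyl group. Among the compounds with values here, since that step is large and the change in compound 3 is larger, a step beyond the scatter is expected, and the direction is taken to be towards a higher number, as no measured compound lacks the carbamoyl. The expected step is an 8.0-fold higher number from compound 2 to compound 3 (0.90 log units; beyond the scatter). For compound 3 the estimate in this assay is 3500 nM, with a range from 700 nM to 18000 nM.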

Compound 3, half-maximal effective concentration: > 20000 nM
Compound 3: a limit, no number (the forecaster's own chance of this, stated with the estimate: 15%); middle value at least 5.7-fold (0.75 log units) away from the limit.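

In this assay compound 3 gives > 20000 nM, which is a limit of the assay and not a number: the limit of > 20000 nM in this assay, at which 1 of the 3 values shown sits. For the compounds shown here, exchanging the whole (3-bromophenyl)carbamoyl for 3-(trifluoromethyl)benzyl on the nitrogen on an aromatic ring gives an at least 45-fold higher number from compound 2 to compound 3 (1.65 log units; beyond the scatter), so this position tolerates far less than the earlier compounds could show, and compound 3 is the only one of the three that ends at a limit. The earlier step, an 18-fold lower number from compound 1 to compound 2 (1.25 log units; beyond the scatter), kept the carbamoyl and changed only a substituent on its aromatic ring, whereas this change shows that replacing the carbamoyl together with its aryl group can take the number past what the read-out gives as a value.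

The exchange alters the carbonyl, the second nitrogen and the ring substituent in a single step, so the compounds shown cannot assign the large step to any one of these parts. Open also is what a (3-(trifluoromethyl)phenyl)carbamoyl, which would keep the carbamoyl while carrying trifluoromethyl, or a plain acetyl or sulfonyl on this nitrogen would give.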